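The source may report more compounds than this note shows. Statements on the series, on what has been measured and on what is new or still open speak of the compounds shown alone.

Series notes. Three analogues sharing one core have been run in an assay on IM-9 cells for displacement of a labelled ligand from Substance-P receptor (Homo sapiens), read by scintillation counting, with a stated time of 30 min; on this read-out higher numbers stand for weaker inhibition and lower numbers for stronger inhibition. Compound 1 `CC(=O)N1CCC(C(=O)N2CC[C@@H](C(=O)N(C)Cc3cc(C(F)(F)F)cc(C(F)(F)F)c3)[C@H](c3ccccc3)C2)CC1` gives 0.098 nM. Compound 2 `CC(=O)N1CCC(C(=O)N2CC[C@H](C(=O)N(C)Cc3cc(C(F)(F)F)cc(C(F)(F)F)c3)[C@@H](c3ccccc3C)C2)CC1` gives 0.032 nM. Compound 3 `CC(=O)NCC(=O)N1CC[C@H](C(=O)N(C)Cc2cc(C(F)(F)F)cc(C(F)(F)F)c2)[C@@H](c2ccc(F)cc2C)C1` gives 0.043 nM; it has the second highest of the three numbers, sits within the scatter of compound 2 and stands beyond the scatter from compound 1, which gives the higher number.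

Compound 4 `Cc1cc(F)ccc1[C@H]1CN(C(=O)C(=O)NO)CC[C@@H]1C(=O)N(C)Cc1cc(C(F)(F)F)cc(C(F)(F)F)c1` differs from compound 3 by hydroxycarbamoyl in place of acetamidomethyl on a carbonyl carbon. Within the three measured compounds, variation at this end of the molecule leaves all values in the same narrow region, so a modest step is expected. The step of a 2.1-fold higher number from compound 3 to compound 4 (0.32 log units; beyond the scatter) is estimated to be small, toward a higher number, at about the edge of the scatter. For compound 4 the expected value in this assay is 0.09 nM, with a range from 0.025 nM to 0.35 nM.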

Compound 4, half-maximal inhibitory concentration: 0.046 nM
Compound 4: middle estimate off by 2.0-fold (0.29 log units), on the high side; measured number inside the range.
By their numbers in this assay, from the lowest: compounds 2, 3 and 4 (each within the scatter of the next); then compound 1.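

In this assay, hydroxycarbamoyl in place of acetamidomethyl on a carbonyl carbon gives a 1.1-fold higher number from compound 3 to compound 4 (0.03 log units; within the scatter). Going by these compounds alone, this is the first single-place step, which the earlier compounds could not provide, and it shows that this exchange leaves the number within the scatter. As far as these compounds go, whether a carboxylic acid, an amine or a longer chain on the same carbonyl carbon would also leave the number there remains open. No measured evidence bears on the reason for this result.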